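This account rests on a few compounds, and the source may have more. Where it says the series, first, only, none or still open, it means among the compounds named here.

In a functional assay on A549 cells (Homo sapiens) for inhibition, read by MTT assay, with a stated time of 24 h (on this read-out higher numbers stand for weaker inhibition and lower numbers for stronger inhibition), compound 2 (`CC1(C)[C@H]2CC[C@]1(C)N(Cc1cn(-c3ccccc3C#N)nn1)C(=O)C2`) gives 100 nM and sits within the scatter of compound 1 (`CC1(C)[C@H]2CC[C@]1(C)N(Cc1cn(-c3ccc(C#N)cc3)nn1)C(=O)C2`), which gives 140 nM in the same read-out. The two numbers therefore cannot be told apart. Compound 3 (`CC1(C)[C@H]2CC[C@]1(C)N(Cc1cn(-c3cccc(C#N)c3)nn1)C(=O)C2`) has yet to be measured. It carries 3-cyanophenyl in place of 2-cyanophenyl on an aromatic nitrogen, with the same atoms joined differently. Among the compounds with values here, the one measured step bearing on this change, a 1.4-fold lower number from compound 1 to compound 2 (0.15 log units; within the scatter) with 2-cyanophenyl in place of 4-cyanophenyl, lies within the scatter. On that single pair, no step beyond the scatter is expected in this assay for 3-cyanophenyl, though one pair is thin evidence. The estimated step is a 1.2-fold higher number from compound 2 to compound 3 (0.08 log units; within the scatter) and stays inside the scatter. For compound 3 the estimate is 120 nM as the expected value, with 60 nM and 240 nM as the ends of the expected range.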

Compound 3, half-maximal inhibitory concentration: 440 nM
Beside the measured number, compound 3's estimate is 3.7-fold (0.56 log units) below it; measured number above the stated range.
By their numbers in this assay, from the lowest: compounds 2 and 1 (each within the scatter of the next); then compound 3.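

In this assay the move to 3-cyanophenyl gives a 4.4-fold higher number from compound 2 to compound 3 (0.64 log units; beyond the scatter) and a 3.1-fold higher number from compound 1 to compound 3 (0.50 log units; beyond the scatter) as well, so the change reaches beyond the scatter against both other groups, which the first pair, within the scatter, could not show. Where the nitrile stands on the phenyl ring therefore counts at this position, even with the same atoms, and compound 3 is the weakest of the three, while compound 1 and compound 2 cannot be told apart. Nothing available here explains why this one arrangement stands apart.

As far as these compounds go, all three compounds keep a nitrile on the phenyl ring, so it stays open how this position would answer to another group in its place, such as a carboxylic acid or an amine. From the compounds shown here alone, it also stays open whether the same order would hold with a group other than nitrile on that ring, such as chlorine.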